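This account rests on a few compounds, and the source may have more. Where it says the series, first, only, none or still open, it means among the compounds named here.

Measured so far:
Compound 1, `COc1cc2ncnc(NNC(=S)NC(=O)c3ccc(F)cc3)c2cc1OC`: 25800 nM in a functional assay on MCF7 cells (Homo sapiens) for cytotoxicity, read by MTT assay, with a stated time of 72 h; on this read-out higher numbers stand for weaker inhibition and lower numbers for stronger inhibition.
Compound 2, `Cc1ccc(C(=O)NC(=S)NNc2ncnc3ccccc23)cc1`: 7820 nM in this assay.

Compound 1 holds the highest of the two numbers in this assay. Its nearest neighbour is compound 2, whose number is lower, and the gap between them lies beyond the usual scatter of this assay. The two structures differ in more than one place, so nothing more is drawn from that gap than what the two values show.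

The unmeasured compound 3, `COc1cc2ncnc(NNC(=S)NC(=O)c3ccccc3Cl)c2cc1OC`, keeps the core of compound 1 and differs from it at the carbonyl end only: 2-chlorophenyl in place of 4-fluorophenyl on a carbonyl carbon. Within the data shown here, no measured pair in this set isolates a change of this kind, so the expectation rests on compound 1 alone. What leaves and what enters have the same counted size, and the step from compound 1 to compound 3 in this assay is expected to be small, with no direction that stands beyond the scatter; it is estimated at a 1.2-fold lower number from compound 1 to compound 3 (0.07 log units; within the scatter). Compound 3 is therefore expected to give about 22000 nM in this assay, within a range of 8000 nM to 60000 nM.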

Compound 3, half-maximal inhibitory concentration: 23100 nM
Compound 3: the middle estimate sits 1.1-fold (0.02 log units) below what was measured, and the stated range covers the measured number.
By their numbers in this assay, from the lowest: compound 2; then compounds 3 and 1 (each within the scatter of the next).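

In this assay the series now holds one step confined to a single place: a 1.1-fold lower number from compound 1 to compound 3 (0.05 log units; within the scatter) with 2-chlorophenyl in place of 4-fluorophenyl on a carbonyl carbon. On the core of compound 1, this read-out therefore does not separate these two groups of equal counted size, a point that the earlier pair, differing in more than one place, could not settle. The step changes the halogen and its place on the phenyl together, so it does not show what either change does alone, and no measurement at hand bears on why the two groups read alike.

Still open, going by these compounds, is how this carbonyl end responds to a group of another kind, such as an amine or a carboxylic acid on the phenyl, or a longer chain in place of the phenyl. Also open, on these data alone, is how much of the gap between compound 2 and compound 1 belongs to the core and how much to the carbonyl end, as the two compounds differ in more than one place.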